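Swapping a piperidine ring for a small aminomethyl group

The source may hold more compounds than are shown below. What is called first, only, known or untested is meant among the compounds shown, and "the series" means these compounds.

- compound 1 `COc1ccccc1-c1csc2cnc(Nc3ccc(NC(=O)C4CCNCC4)cc3)nc12`: 1060 nM
- compound 2 `COc1ccccc1-c1csc2cnc(Nc3ccc(NC(=O)[C@@H]4CCCNC4)cc3)nc12`: 360 nM

In a functional assay on U-87MG ATCC cells for inhibition, with U-87 MG (Homo sapiens) as the target, read by MTT assay, with a stated time of 72 h (a lower number here means a stronger inhibitor, a higher number a weaker inhibitor), compound 2 gives the lower of the two numbers, 360 nM. Compound 3 `COc1ccccc1-c1csc2cnc(Nc3ccc(NC(=O)CN)cc3)nc12` has aminomethyl in place of piperidin-3-yl on a carbonyl carbon. For the measured compounds named here, only one measured step bears on this site: a 2.9-fold lower number from compound 1 to compound 2 (0.47 log units; beyond the scatter), a modest change that keeps the ring. Going by the values given here, no measured compound lacks the ring, so the direction is uncertain, but a step of similar size towards a higher number seems likely. The expected step is a 2.8-fold higher number from compound 2 to compound 3 (0.44 log units; beyond the scatter). For compound 3 the estimated value is 1000 nM, with an expected range of 300 nM to 3500 nM.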

Compound 3, half-maximal inhibitory concentration: 210 nM
For compound 3 the middle estimate is 4.8-fold (0.68 log units) above the measured one; measured number below the stated range.
By their numbers in this assay, from the lowest: compounds 3 and 2 (each within the scatter of the next); then compound 1.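

In this assay the piperidine ring proves dispensable at this position: on the carbonyl carbon, the much smaller aminomethyl group gives a 1.7-fold lower number from compound 2 to compound 3 (0.23 log units; within the scatter), so piperidin-3-yl and aminomethyl cannot be told apart. Compared with piperidin-4-yl, the same group gives a 5.0-fold lower number from compound 1 to compound 3 (0.70 log units; beyond the scatter), a modest gain. Nothing available explains these results.

Going by these compounds, it remains open whether a longer chain such as aminoethyl or a dimethylaminomethyl group would perform similarly. On these data alone, it is also open whether a hydroxymethyl group could replace aminomethyl, which would test the need for the amine.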